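Swapping an amino alcohol for a pyrrolidine chain

A few compounds are considered here, and "the series" means these few. Any claim that something is new, unique, unknown or untested is made for them only; others in the source may bear on it.

Compound 2 `CCCCCCCCCCc1ccc(-c2noc(CC(O)CN)n2)cc1` gives 59% in an assay on HeLa cells for inhibition of sphingosine-1-phosphate transporter SPNS2 (Mus musculus), read by LC-MS, tested at 2 uM (on this read-out lower numbers stand for less inhibition and higher numbers for more inhibition at the one concentration tested (going by the name of the read-out)), the higher of the two measured values. Compound 1 `CCCCCCCCCCc1ccc(-c2noc(CC3CCNC3)n2)cc1` gives 44% in this assay, and the step of a number 15 percentage points higher from compound 1 to compound 2 (beyond the scatter) came with 2-amino-1-hydroxyethyl in place of pyrrolidin-3-yl. Compound 3 `CCCCCCCCCCc1ccc(-c2noc(CCCN3CCCC3)n2)cc1` differs from compound 2 by 2-(pyrrolidin-1-yl)ethyl in place of 2-amino-1-hydroxyethyl on a saturated chain carbon bound to an aromatic carbon. Here the hydrogen-bond donors leave and a five-membered ring enters, so the only measured step bears on this change in reverse. For compound 3 a modest drop in this assay is expected, a number 14 percentage points lower from compound 2 to compound 3 (beyond the scatter). Compound 3 is estimated at 45%, within 25% to 65%.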

Compound 3, a percentage reported as inhibition, at one concentration (the size of the read-out at that concentration, not a potency): 3%
For compound 3 the middle estimate is 42 percentage points above the measured one; the measured number lies below the stated range.
By their numbers in this assay, from the lowest: compound 3; then compound 1; then compound 2.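

In this assay this chain position proves far less forgiving than the modest first step suggested: there is a number 56 percentage points lower from compound 2 to compound 3 (beyond the scatter), and also a number 41 percentage points lower from compound 1 to compound 3 (beyond the scatter). Both steps are large, so 3-(pyrrolidin-1-yl)propyl stands out among the three groups compared here. Nothing measured here explains this loss.

On these data alone, the change from compound 2 to compound 3 alters the hydroxyl, the primary amine and the ring at once, so their separate contributions remain open. A plain 3-aminopropyl chain without the hydroxyl would begin to separate them.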